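The compounds below may be only part of what the source reports. "The series", "measured", "known", "first", "only" and "open" are said of these compounds alone.

Measured in a functional assay on PC-3 cells (Homo sapiens), read by MTT assay, with a stated time of 48 h; on this read-out higher numbers stand for weaker inhibition and lower numbers for stronger inhibition:
- compound 1 `CCn1c(C(=O)NCCCN(C)C)ccc1C(CC)(CC)c1ccc(OCC(O)C(C)(C)C)c(C)c1` gives 3100 nM
- compound 2 `CCn1c(C(=O)NCCN)ccc1C(CC)(CC)c1ccc(OCC(O)C(C)(C)C)c(C)c1` gives 940 nM
- compound 3 `CCn1c(C(=O)N(C)CCC#N)ccc1C(CC)(CC)c1ccc(OCC(O)C(C)(C)C)c(C)c1` gives 1700 nM

Compound 3 stands within the scatter of both other compounds, as shown by a 1.8-fold lower number from compound 1 to compound 3 (0.26 log units; within the scatter) and by a 1.8-fold higher number from compound 2 to compound 3 (0.26 log units; within the scatter). The next compound is compound 4 `C=CCN(C)C(=O)c1ccc(C(CC)(CC)c2ccc(OCC(O)C(C)(C)C)c(C)c2)n1CC`, with vinyl in place of cyanomethyl on a saturated chain carbon bound to an amide-type nitrogen. The same difference also reads 2-cyanoethyl to allyl.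

For the measured compounds named here, no measured step makes this exchange. The closest evidence is the pair of steps above, in which the whole group on the carbonyl carbon changes and the number stays within the scatter. Going by the values given here, the only step beyond the scatter, a 3.3-fold lower number from compound 1 to compound 2 (0.52 log units; beyond the scatter), is modest and involves different groups. No step beyond the scatter is therefore expected in this assay. The expected step is a 1.1-fold lower number from compound 3 to compound 4 (0.03 log units; within the scatter). For compound 4 the estimated value is 1600 nM, with an expected range of 700 nM to 3700 nM.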

Compound 4, half-maximal inhibitory concentration: 25900 nM
The estimate for compound 4 lay 16-fold (1.21 log units) below the measured number, outside the stated range (above it).
By their numbers in this assay, from the lowest: compounds 2, 3 and 1 (each within the scatter of the next, the first and the last beyond it); then compound 4.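

In this assay, for the compounds shown here, the group on the saturated chain carbon bound to an amide-type nitrogen proves decisive in a way the earlier compounds did not show: vinyl in place of cyanomethyl gives a 15-fold higher number from compound 3 to compound 4 (1.18 log units; beyond the scatter), although this exchange alters only the end of the chain. The other comparisons place compound 4 apart as well, with a 28-fold higher number from compound 2 to compound 4 (1.44 log units; beyond the scatter) and an 8.4-fold higher number from compound 1 to compound 4 (0.92 log units; beyond the scatter). No measurement at hand accounts for the size of this step.

Still open, as far as these compounds go, is whether the change follows from the nitrile leaving or from the vinyl entering; an ethyl or a methoxymethyl group at that chain carbon would separate the two. Also open, from the compounds shown here alone, is how a primary amine or a carboxylic acid at that carbon, with the amide methyl kept, would read out.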